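A few compounds are considered here, and "the series" means these few. Any claim that something is new, unique, unknown or untested is made for them only; others in the source may bear on it.

Working notes on the oxazolidinone series.

Compound 1 `CN(CCC#N)C[C@H]1CN(c2ccc(-n3cc(-c4ccccn4)cn3)c(F)c2)C(=O)O1` and compound 2 `O=C1CCC(=O)N1C[C@H]1CN(c2ccc(-n3cc(-c4ccccn4)cn3)c(F)c2)C(=O)O1` share one core and differ only on the saturated chain carbon bound to a saturated ring carbon. In a physicochemical assay for solubility, read by HPLC, with a stated time of 24 h (on this read-out higher numbers stand for higher solubility and lower numbers for lower solubility), compound 1 gives 64500 nM; in this assay compound 2 gives 45300 nM. The step of a 1.4-fold lower number from compound 1 to compound 2 (0.15 log units; within the scatter) is the only one measured so far, and it lies within the scatter. Compound 2 therefore stands at the lower of the two numbers, with compound 1 within the scatter of it, so no order between the two can be claimed.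

Compound 3 `O=C1CNC(=O)N1C[C@H]1CN(c2ccc(-n3cc(-c4ccccn4)cn3)c(F)c2)C(=O)O1` is the next analogue. Its difference from compound 2 is 2,5-dioxoimidazolidin-1-yl in place of 2,5-dioxopyrrolidin-1-yl on a saturated chain carbon bound to a saturated ring carbon; cut one bond further out, the change reads (2,5-dioxopyrrolidin-1-yl)methyl to (2,5-dioxoimidazolidin-1-yl)methyl. The change keeps the ring size and both carbonyls and brings one hydrogen-bond donor into the five-membered ring. Among the measured compounds shown here, the one step on record at this position, a 1.4-fold lower number from compound 1 to compound 2 (0.15 log units; within the scatter), swapped a much larger difference than this and still stayed within the scatter, so for compound 3 a step in this assay that stays within the scatter, in either direction, is the expectation, written as a 1.1-fold higher number from compound 2 to compound 3 (0.04 log units; within the scatter). The solubility of compound 3 in this assay is estimated at 50000 nM, with a range from 25000 nM to 100000 nM.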

Compound 3, solubility: 1630000 nM
Compound 3: the middle estimate sits 33-fold (1.51 log units) below what was measured; measured number above the stated range.
By their numbers in this assay, from the lowest: compounds 2 and 1 (each within the scatter of the next); then compound 3.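

In this assay, the saturated chain carbon bound to a saturated ring carbon turns out to carry a large step, which the earlier pair did not show: a 36-fold higher number from compound 2 to compound 3 (1.56 log units; beyond the scatter) comes from the exchange of 2,5-dioxopyrrolidin-1-yl for 2,5-dioxoimidazolidin-1-yl, a change that keeps the heavy-atom count and the five-membered ring and brings in a second ring hetero atom and a hydrogen-bond donor. Compound 3 also stands clear of the amine-bearing analogue, with a 25-fold higher number from compound 1 to compound 3 (1.40 log units; beyond the scatter), so among these three compounds the size of a step does not follow how much of the group is exchanged, since the very different groups of compound 1 and compound 2 remain within the scatter of each other. Nothing on record explains the size of this step.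

The compounds shown leave open whether the step depends on the amide hydrogen of the 2,5-dioxoimidazolidin-1-yl ring, which a methyl group on that ring nitrogen would test. They also leave open how a primary amine, a carboxylic acid or a longer chain at this place would read in this assay.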